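Working notes: adding chloro to compound 1

The source may report more compounds than this note shows. Statements on the series, on what has been measured and on what is new or still open speak of the compounds shown alone.

Values so far in an ADME assay on HOS cells (Homo sapiens) for cytotoxicity; a higher number here means a weaker inhibitor, a lower number a stronger inhibitor:
- compound 1 (`O=C1c2c(ccc(O)c2O)CN1Cc1ccc(F)cc1`): "not determined" (no result reported)
- compound 2 (`O=C1c2ccc(O)c(O)c2C(=O)N1Cc1ccc(F)c(F)c1`): 7940 nM
- compound 3 (`O=C1c2c(ccc(O)c2O)CN1Cc1cc(F)ccc1F`): 13400 nM

Compound 1 has no reported result in this assay and so has no place on the numbers yet. The step discussed here therefore has no measured starting point. Among the measured compounds shown here, the only numbers available come from compound 2 (7940 nM) and compound 3 (13400 nM), and these two values lie within the usual scatter of each other.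

Compound 4 (`O=C1c2c(ccc(O)c2O)CN1Cc1ccc(F)c(Cl)c1`) is compound 1 with a single change (chloro in place of hydrogen on an aromatic carbon): chloro in place of hydrogen on an aromatic carbon, ortho to a fluoro group and meta to a large group. For the measured compounds named here, no pair of measured compounds shows this change, so the data offer no direct precedent for its size.

In this assay the expectation is therefore a step no larger than the scatter, in neither direction, from the level set by compound 2 (7940 nM) and compound 3 (13400 nM). That level is only a stand-in for the missing value of compound 1, so the range is kept wide. For compound 4 the expected value is 10000 nM, with an estimated range of 4000 nM to 25000 nM.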

Compound 4, half-maximal inhibitory concentration: 6870 nM
For compound 4 the middle estimate is 1.5-fold (0.16 log units) above the measured one; the range from low to high includes it.
By their numbers in this assay, from the lowest: compounds 4, 2 and 3 (each within the scatter of the next).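

Among the compounds shown here, compound 1 carries no single number in this assay, so no step to compound 4, which gives 6870 nM, can be read. The compounds shown leave open how large the effect of chloro in place of hydrogen is on compound 1, and in which direction it runs. No supporting evidence bears on this result.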